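The source may hold more compounds than are shown below. What is called first, only, known or untested is meant among the compounds shown, and "the series" means these compounds.

Measured compounds:
- compound 1 `CCOc1cc(NC(=O)C2(NC(=O)c3ccc4c(C5CCCC5)c(-c5ncc(Cl)cn5)n(C)c4c3)CCC2)ccc1/C=C/C(=O)N[C@@H](CC(=O)O)C(N)=O`: > 5 h
- compound 2 `CCOC(=O)/C=C/c1ccc(NC(=O)C2(NC(=O)c3ccc4c(C5CCCC5)c(-c5ncc(Cl)cn5)n(C)c4c3)CCC2)cc1OCC`: 0.333 h

In an ADME assay on stomach for pharmacokinetics, in simulated gastric fluid (a lower number here means that the compound disappears faster, a higher number that the compound lasts longer), compound 1 reaches only a limit of the assay, > 5 h. Compound 2 gives 0.333 h in this assay, and it is the only number shown. Among the compounds with values here, the one further value shown, that of compound 1, is a limit of the assay. Within the data shown here, the single measured step, an at least 15-fold lower number from compound 1 to compound 2 (1.17 log units; beyond the scatter), replaced the (1-carbamoyl-2-carboxyethyl)amino group on the carbonyl carbon by ethoxy; the limit described by the limit of > 5 h in this assay, at which 1 of the 2 values shown sits, means the true size of that step is not known.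

Compound 3 `CCOc1cc(NC(=O)C2(NC(=O)c3ccc4c(C5CCCC5)c(-c5ncc(Cl)cn5)n(C)c4c3)CCC2)ccc1/C=C/C(=O)OCC(C)C` differs from compound 2 by isopropyl in place of methyl on a saturated chain carbon bound to an oxygen next to a carbonyl group. The ethoxycarbonyl group of compound 2 thus becomes an isobutoxycarbonyl group while the carbonyl and its oxygen stay. Among the measured compounds shown here, no measured step covers such a change within the ester alkyl chain; the step from compound 1 to compound 2 concerns the exchange of the amide for the ester itself and bears on it only loosely. The expected step is therefore a 1.5-fold higher number from compound 2 to compound 3 (0.18 log units; within the scatter), which is not expected to go beyond the scatter. Compound 3 is estimated at 0.5 h in this assay, within a range from 0.2 h to 1.5 h.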

Compound 3, half-life: 1.43 h
For compound 3 the middle estimate is 2.9-fold (0.46 log units) below the measured one, and the stated range covers the measured number.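

In this assay, the alkyl part of the ester proves to matter on its own: with the carbonyl and its oxygen unchanged, exchanging ethoxycarbonyl for isobutoxycarbonyl gives a 4.3-fold higher number from compound 2 to compound 3 (0.63 log units; beyond the scatter). The isobutoxy group still does not match the (1-carbamoyl-2-carboxyethyl)amino group on the same carbonyl carbon, with an at least 3.4-fold lower number from compound 1 to compound 3 (0.54 log units; beyond the scatter). Compound 1 stands at a limit, so the true size of that step remains unknown: the limit of > 5 h in this assay, at which 1 of the 3 values shown sits.

With only ethyl and isobutyl to compare, the trend along the ester chain remains undefined, and a straight butyl chain, a tert-butyl group or a benzyl group could help separate the length of the chain from its branching. Also open, going by these compounds, is where a free carboxylic acid or a simple primary amide on this carbonyl carbon would fall in this assay, and so whether the whole (1-carbamoyl-2-carboxyethyl)amino group is needed to reach the range of compound 1.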